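Series notes: chlorophenyl isomers and cytotoxicity

This account rests on a few compounds, and the source may have more. Where it says the series, first, only, none or still open, it means among the compounds named here.

The shared core carries a 2,4-difluorophenyl group and a variable aryl group; the read-out throughout is an ADME assay on Huh-7 cells (Homo sapiens) for cytotoxicity; a lower number here means that less compound is tolerated, a higher number that more compound is tolerated. Compound 1 `CN1CCN(CCNCc2cn(-c3ccc(F)cc3F)nc2-c2ccc(OC(F)(F)F)cc2)CC1` gives 18000 nM in this assay. Compound 2 `CN1CCN(CCNCc2cn(-c3ccc(F)cc3F)nc2-c2ccccc2)CC1` reaches only a limit in this assay, > 20000 nM (the limit of > 20000 nM in this assay, at which 1 of the 3 values shown sits). Compound 3 `CN1CCN(CCNCc2cn(-c3ccc(F)cc3F)nc2-c2cccc(Cl)c2)CC1` gives 15000 nM and stands as the lowest of the two numbers reported, within the scatter of compound 1: a 1.2-fold lower number from compound 1 to compound 3 (0.08 log units; within the scatter), and an at least 1.1-fold higher number from compound 1 to compound 2 (0.04 log units; that floor lies within the scatter), while an at least 1.3-fold lower number from compound 2 to compound 3 (0.12 log units; that floor lies within the scatter). None of these steps leaves the scatter. Compound 4 `CN1CCN(CCNCc2cn(-c3ccc(F)cc3F)nc2-c2ccccc2Cl)CC1` is not yet measured; it differs from compound 3 by 2-chlorophenyl in place of 3-chlorophenyl on an aromatic carbon. Among the measured compounds shown here, no measured step exchanges two chlorophenyl isomers, so the closest guides are the three steps among compounds 1, 2 and 3, all within the scatter; the expected step of no change at the digits printed from compound 3 to compound 4 (within the scatter) is therefore none beyond the scatter. Compound 4 is estimated at 15000 nM, with a range of 7500 nM to 30000 nM in this assay.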

Compound 4, half-maximal cytotoxic concentration: > 20000 nM
Compound 4: only a limit was reported; the forecaster's own chance of this, stated with the estimate: 25%; at least 1.3-fold (0.12 log units) between middle value and limit.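

The exchange of 3-chlorophenyl for 2-chlorophenyl, the only isomer pair shown at this position, gives an at least 1.3-fold higher number from compound 3 to compound 4 (0.12 log units; that floor lies within the scatter) in this assay, and the comparison with the 4-(trifluoromethoxy)phenyl compound gives an at least 1.1-fold higher number from compound 1 to compound 4 (0.04 log units; that floor lies within the scatter), so neither floor separates these aryl groups beyond the scatter. The step between compound 2 and compound 4 cannot be read, as both values are limits. Compound 4 carries a limit and not a number, and it is the second compound in the set to do so: the limit of > 20000 nM in this assay, at which 2 of the 4 values shown sit.

Going by these compounds, what remains open is how far compound 2 and compound 4 lie from that limit, and so whether 2-chlorophenyl truly differs from 3-chlorophenyl. Also open, on these data alone, is whether 4-chlorophenyl, or a phenyl bearing an amine or a carboxylic acid, would leave the scatter at this position.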